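The source may hold more compounds than are shown below. What is called first, only, known or untested is meant among the compounds shown, and "the series" means these compounds.

Measured compounds:
Compound 1 `CN(C)c1ccc2c(=O)c(C(=O)Nc3cc(F)cc(F)c3)cn(-c3ccc(OCCCCCCC[N+]4(C)CCCC4)cc3Cl)c2n1` gives "not active" (no number reported) in an assay on LX2 cells for inhibition of COL1A1 promoter (Homo sapiens), read by a luciferase reporter, with a stated time of 24 h, tested at 20 uM; a lower number here means a weaker effect, a higher number a stronger effect of the compound at the concentration tested.
Compound 2 `Cc1cc(OCCCCCCC[N+]2(C)CCCCC2)cc(-n2cc(C(=O)Nc3cc(F)cc(F)c3)c(=O)c3ccc(N(C)C)nc32)c1` gives 46.8% in this assay.
Compound 3 `CN1CC[N+](C)(CCCCCCCOc2ccc(-n3cc(C(=O)Nc4cc(F)cc(F)c4)c(=O)c4ccc(N(C)C)nc43)c(F)c2)CC1` gives "not active" (no number reported) in this assay.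

Among these three, compound 2 is the only one with a number in this assay; compound 1 and compound 3 are reported without a figure. Going by the values given here, no pair of the measured compounds differs in a single place, so no measured step is available to anchor a prediction.

Compound 4 `Cc1cc(OCCCCCCC[N+](C)(C)C2CCCCC2)cc(-n2cc(C(=O)Nc3cc(F)cc(F)c3)c(=O)c3ccc(N(C)C)nc32)c1` differs from compound 2 by a group of 9 heavy atoms (8 carbon, 1 nitrogen; one six-membered non-aromatic ring of carbon only) in place of a group of 7 heavy atoms (6 carbon, 1 nitrogen; one six-membered non-aromatic ring with 1 hetero atom), on a saturated chain carbon, seven bonds along the chain from an oxygen on an aromatic ring. Both the leaving and the entering group carry the same charge and the same absence of hydrogen-bond donors and acceptors, and the change sits far out on the chain, seven bonds along from the aromatic oxygen. In the absence of any measured step, the expected change from compound 2 to compound 4 is estimated as small, likely within the usual scatter, with no clear direction: a number 2.8 percentage points lower from compound 2 to compound 4 (within the scatter). Compound 4 is therefore estimated to give 44% in this assay, within a range from 24% to 62%.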

Compound 4, a percentage reported as inhibition, at one concentration (the size of the read-out at that concentration, not a potency): 52.5%
For compound 4 the middle estimate is 8.5 percentage points below the measured one; the measured number falls inside the stated range.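

In this assay, replacing the end group gives a number 5.7 percentage points higher from compound 2 to compound 4 (within the scatter). This is the first measured step among these compounds, and it shows that, on a saturated chain carbon, seven bonds along the chain from an oxygen on an aromatic ring, this read-out does not separate the six-membered non-aromatic ring of carbon only, in the entering group, from the six-membered non-aromatic ring with 1 hetero atom, in the leaving group. No measurement of any other kind is available to bear on this result.

The compounds shown leave open whether the end of the chain would accept an uncharged dimethylamino group or a carboxylic acid, or whether a shorter or longer chain would hold the read-out. They also cannot say why compound 1 and compound 3 carry no figure, since each differs from compound 2 in more than one place.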